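The compounds below may be only part of what the source reports. "The series", "measured", "known", "first", "only" and "open" are said of these compounds alone.

Two compounds have numbers in a functional assay on the whole organism (Tail, strain ICR) with Mus musculus as the target, in the tail flick test, with a stated time of 150 min, at a dose of 25 umol/kg by the oral route; a lower number here means a weaker effect, a higher number a stronger effect of the compound at the dose given. Compound 1 `O=C(CN(c1nc(Cl)nc2[nH]cnc12)C1CC1)N[C@@H](CC(=O)OCc1ccccc1)C(=O)OCc1ccccc1` gives 6.68%. Compound 2 `CC[C@H](C)[C@H](NC(=O)CN(c1ncnc2c1ncn2C1CCCCO1)C1CC1)C(=O)OCc1ccccc1` gives 16.4%, the larger of the two, though the gap to compound 1 lies within the scatter, so no order between them can be read. Compound 3 `O=C(CN(c1ncnc2c1ncn2C1CCCCO1)C1CC1)N[C@@H](CC(=O)OCc1ccccc1)C(=O)OCc1ccccc1` carries the side chain of compound 1 on the core of compound 2; the change from compound 2 is (benzyloxycarbonyl)methyl in place of sec-butyl on a saturated chain carbon bound to an amide-type nitrogen and a carbonyl carbon. The step is expected to be downward and small, a number 7.4 percentage points lower from compound 2 to compound 3 (within the scatter), not clearly beyond the scatter. Compound 3 is estimated at 9%, with a range from 0% to 22%.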

Compound 3, a percentage reported as activity, at one dose (the size of the read-out at that dose, not a potency): 0.06%
Compound 3: middle estimate off by 8.9 percentage points, on the high side; measured number inside the range.
By their numbers in this assay, from the lowest: compounds 3, 1 and 2 (each within the scatter of the next, the first and the last beyond it).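

In this assay, (benzyloxycarbonyl)methyl in place of sec-butyl gives a number 16.3 percentage points lower from compound 2 to compound 3 (beyond the scatter), so the group on this saturated chain carbon can move the read-out on the shared core. The gap between compound 1 and compound 2 could not show this, as those two differ in more than one place. Nothing at hand bears on why the number falls with this change.

From the compounds shown here alone, whether the same change lowers the number on the core of compound 1 stays open. So does the outcome with a carboxylic acid or an amine at this place.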